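Oral Tail Flick Activity: From Compound 1 to Compound 4

A few compounds are considered here, and "the series" means these few. Any claim that something is new, unique, unknown or untested is made for them only; others in the source may bear on it.

Of the compounds shown here, three have been measured in a functional assay on the whole organism (Tail, strain ICR) with Mus musculus as the target, in the tail flick test, with a stated time of 60 min, at a dose of 25 umol/kg by the oral route; on this read-out lower numbers stand for a weaker effect and higher numbers for a stronger effect at the one dose given. Compound 1, with the structure `O=C(CN(c1nc(Cl)nc2[nH]cnc12)C1CC1)N[C@@H](CC(=O)OCc1ccccc1)C(=O)OCc1ccccc1`, gives 22.4%. Compound 2, `O=C(OCc1ccccc1)[C@@H]1CCCN1C(=O)CN(c1ncnc2c1ncn2C1CCCCO1)C1CC1`, gives 36.7%, and compound 3, `NC(=O)C[C@H](NC(=O)CN(c1ncnc2c1ncn2C1CCCCO1)C1CC1)C(=O)OCc1ccccc1`, gives 30.5%. Compound 1 carries the lowest number of the three; its gap to compound 3 lies within the scatter of repeated measurements, while its gap to compound 2 lies beyond it. Among the measured compounds shown here, no two of these measured compounds differ in only one place, so no single measured step shows how one change alone moves this assay.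

Compound 4, `CC(C)C[C@H](NC(=O)CN(c1nc(Cl)nc2[nH]cnc12)C1CC1)C(=O)OCc1ccccc1`, differs from compound 1 in one place: isopropyl in place of benzyloxycarbonyl on a saturated chain carbon, two bonds along the chain from an amide-type nitrogen and a carbonyl carbon. A chain group with an aromatic ring and two hydrogen-bond acceptors gives way to a small saturated one with none. Nothing measured here shows the effect of this change, so the expectation must rest on the spread of the three numbers alone. The expected step is a number 5.6 percentage points higher from compound 1 to compound 4 (within the scatter), which stays within the usual scatter. Compound 4 is therefore estimated to give 28% in this assay, with a likely range from 12% to 45%.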

Compound 4, a percentage reported as activity, at one dose (the size of the read-out at that dose, not a potency): 27.3%
Estimate against measurement, compound 4: 0.7 percentage points above; the measured number falls inside the stated range.
By their numbers in this assay, from the lowest: compounds 1, 4, 3 and 2 (each within the scatter of the next, the first and the last beyond it).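

Among the compounds shown here, this is the first pair that differs in only one place, so the effect of a single change can now be read: on the saturated chain carbon, two bonds along the chain from an amide-type nitrogen and a carbonyl carbon, isopropyl replaces benzyloxycarbonyl, and in this assay the step stays within the scatter (a number 4.9 percentage points higher from compound 1 to compound 4 (within the scatter)). The group that leaves has 10 heavy atoms, a six-membered aromatic ring and 2 hydrogen-bond acceptors, while the group that enters has 3 heavy atoms, no ring and 0 hydrogen-bond acceptors, so this large difference in the group does not show up as a clear change in the read-out at this one dose. Nothing measured on the compounds themselves explains this result.

Still open, from the compounds shown here alone, is how a carboxylic acid, an amine or a longer saturated chain would read on this same chain carbon. Also open, going by these compounds, is whether isopropyl in place of benzyloxycarbonyl would give a similar step on the core of compound 2, which carries a different group on that core.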